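This account rests on a few compounds, and the source may have more. Where it says the series, first, only, none or still open, it means among the compounds named here.

Working notes on the series. Compound 1 `Cc1cc(Nc2ccc(C(=O)/C=C/c3ccc4ccccc4c3)cc2)n2nc(SCc3cccc4ccccc34)nc2n1` gives 68 nM in a functional assay on SW-620 cells (Homo sapiens) for cytotoxicity, read by MTT assay, with stated times of 4 h and 72 h, tested at 2 uM; on this read-out higher numbers stand for weaker inhibition and lower numbers for stronger inhibition. Compound 3 `Cc1cc(Nc2ccc(C(=O)/C=C/c3ccc4ccccc4c3)cc2)n2nc(SCC(=O)c3ccccc3)nc2n1` gives 190 nM in this assay, and compound 2 `Cc1cc(Nc2ccc(C(=O)/C=C/c3ccc(OC(F)(F)F)cc3)cc2)n2nc(SCc3nc4ccccc4[nH]3)nc2n1` gives 220 nM. Compound 2 thus stands at the highest number of the three measured; its gap to compound 3 lies within the scatter, while its gap to compound 1 lies beyond it. For the measured compounds named here, the only single-place step measured so far is a 2.8-fold higher number from compound 1 to compound 3 (0.45 log units; beyond the scatter), which concerns the group on the saturated chain carbon bound to sulfur, not the place of the change now in hand. Compound 4 `COc1ccc(/C=C/C(=O)c2ccc(Nc3cc(C)nc4nc(SCc5nc6ccccc6[nH]5)nn34)cc2)cc1F` differs from compound 2 by 3-fluoro-4-methoxyphenyl in place of 4-(trifluoromethoxy)phenyl on a double-bonded chain carbon bound to a double-bonded chain carbon. Going by the values given here, no measured pair isolates a change at this place: compound 1 and compound 2 differ both here and at the sulfur-bound carbon, so their values cannot be split between the two changes. Among the compounds with values here, with no bearing step, no shift beyond the scatter is expected in this assay. Compound 4 is therefore estimated at 200 nM, with a range from 80 nM to 500 nM. This corresponds to an expected step of a 1.1-fold lower number from compound 2 to compound 4 (0.04 log units; within the scatter).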

Compound 4, half-maximal inhibitory concentration: 140 nM
Beside the measured number, compound 4's estimate is 1.4-fold (0.15 log units) above it, within the range that was stated.
By their numbers in this assay, from the lowest: compound 1; then compounds 4, 3 and 2 (each within the scatter of the next).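

In this assay, for the compounds shown here, the first single-place step at this position, a 1.6-fold lower number from compound 2 to compound 4 (0.20 log units; within the scatter), stays within the scatter, so 3-fluoro-4-methoxyphenyl and 4-(trifluoromethoxy)phenyl cannot be told apart here on a double-bonded chain carbon bound to a double-bonded chain carbon. Going by these compounds alone, compound 1 and compound 2 differ at two places and could not isolate this position; this pair does, although it gives only one exchange with one group on the sulfur-bound carbon. Nothing available accounts for the result or links it to any property of either group.

The compounds shown leave open how this position responds to a phenyl ring carrying an amine or a carboxylic acid. On these data alone, it is also open whether this exchange gives a similar result with the sulfur-bound groups of compound 1 and compound 3.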